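The source may report more compounds than this note shows. Statements on the series, on what has been measured and on what is new or still open speak of the compounds shown alone.

Measured compounds:
Compound 1 `Cc1c(OCCCCOc2ccc(C(=O)O)cc2F)ccc(C(=O)CC(C)C)c1O`: 57%
Compound 2 `Cc1c(OCCCCOc2cccc(C(=O)O)c2)ccc(C(=O)CC(C)C)c1O`: 51%

In an ADME assay (liver) for metabolic stability, with Liver microsome (Rattus norvegicus) as the target, read by LC-MS, using microsomes and NADPH, with stated times of 5 min and 60 min, tested at 4 uM (on this read-out lower numbers stand for a less stable compound and higher numbers for a more stable compound), compound 2 at 51% lies within the scatter of compound 1 at 57%. Compound 3 `Cc1cc(OCCCCOc2ccc(C(=O)CC(C)C)c(O)c2C)ccc1C(=O)O` differs from compound 2 by one change: 4-carboxy-3-methylphenyl in place of 3-carboxyphenyl on an oxygen on a saturated carbon. Going by the values given here, no measured compound carries 4-carboxy-3-methylphenyl. Among the compounds with values here, the one measured step that bears on this, a number 6 percentage points lower from compound 1 to compound 2 (within the scatter), exchanges the group at the same place, and it stays within the scatter. No step beyond the scatter is therefore expected in this assay. The expected step is a number 1 percentage points higher from compound 2 to compound 3 (within the scatter). For compound 3 the estimate is 52%, with an expected range of 36% to 68%.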

Compound 3, percent of the compound remaining: 57%
The estimate for compound 3 lay 5 percentage points below the measured number; the measured number falls inside the stated range.
By their numbers in this assay, from the lowest: compounds 2, 1 and 3 (each within the scatter of the next).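

In this assay, 4-carboxy-3-methylphenyl on an oxygen on a saturated carbon gives a number 6 percentage points higher from compound 2 to compound 3 (within the scatter) and also no change at the digits printed from compound 1 to compound 3 (within the scatter) in the comparison with 4-carboxy-2-fluorophenyl. All three carboxyl-bearing rings at this place therefore lie within the scatter of one another, so the added methyl brings no step beyond it. Nothing available explains why the read-out holds here.

Going by these compounds, whether a ring carrying a primary amide or a tetrazole in place of the carboxylic acid would stay within the scatter remains open. So does the effect of a longer chain on that oxygen.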